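The source may hold more compounds than are shown below. What is called first, only, known or untested is meant among the compounds shown, and "the series" means these compounds.

The measured compounds, each in a functional assay on A549 cells (Homo sapiens) for inhibition, read by MTT assay, with a stated time of 72 h; on this read-out higher numbers stand for weaker inhibition and lower numbers for stronger inhibition:

Compound 1 `C=C(c1ccc(F)c(F)c1)C1COC(C)(C)OO1`; compound 1 gives > 100000 nM, which is a limit of the assay and not a number.
Compound 2 `C=C(c1ccc(OC)c(F)c1)C1COC(C)(C)OO1`; compound 2 gives 100000 nM.
Compound 3 `C=C(c1ccc(OC)c(F)c1)C1COC2(CCCC2)OO1`; compound 3 gives 9700 nM.

Compounds 1 and 2 share one core and differ in a single place: fluoro in place of methoxy on an aromatic carbon. This change gave a number no lower from compound 2 to compound 1 (the limit leaves the size open); the size of that step cannot be read because of the limit of > 100000 nM in this assay, at which 1 of the 3 values shown sits. Compound 3 has a different core, and how the two cores differ is not broken down here. Among the two numbers, compound 3 has the lower one, and its gap to compound 2 lies beyond the usual scatter.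

Compound 4 `C=C(c1ccc(F)c(F)c1)C1COC2(CCCC2)OO1` has not been measured. It differs from compound 3 by fluoro in place of methoxy on an aromatic carbon, the same change as that between compound 2 and compound 1, at the same kind of place. In this assay compound 4 is estimated to give 30000 nM, expected to fall between 8000 nM and 120000 nM. This expectation means a step of a 3.1-fold higher number from compound 3 to compound 4 (0.49 log units; beyond the scatter), and it rests on the earlier pair in which the same change gave a number no lower from compound 2 to compound 1 (the limit leaves the size open).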

Compound 4, half-maximal inhibitory concentration: 11700 nM
Estimate against measurement, compound 4: 2.6-fold (0.41 log units) above, within the range that was stated.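

In this assay fluoro in place of methoxy gave a 1.2-fold higher number from compound 3 to compound 4 (0.08 log units; within the scatter) and so, on the core of compound 3, the swap leaves a difference too small to tell apart from repeat measurement. Compound 1 gives > 100000 nM as a limit of the assay and not a number, so the step on the other core cannot be read: the limit of > 100000 nM in this assay, at which 1 of the 4 values shown sits.

This shows what the swap does on one core only, and it does not show whether that result carries over to the other core, where the two steps can only be set side by side: the same change on two cores in this assay, a number no lower (the limit leaves the size open) from compound 2 to compound 1 and a 1.2-fold higher number (0.08 log units; within the scatter) from compound 3 to compound 4; the limit leaves it open whether they differ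

The compounds shown leave open what other groups would do at this place on the aromatic ring, such as an amine, a carboxylic acid or a longer chain. Going by these compounds, all of them also keep the same fluoro group on the ring, so it remains open whether the swap would read the same with that group replaced by a hydrogen.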